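Swapping the Distal Aryl Ring in a Cytotoxicity Series

The source may report more compounds than this note shows. Statements on the series, on what has been measured and on what is new or still open speak of the compounds shown alone.

Going by the values given here, compound 3 `COc1cccc(-c2cccc(COc3ccc4c(c3)[C@@H](O)CN(C)C4)c2)c1` is the only compound with a definite number in an ADME assay on Vero cells (Chlorocebus sabaeus) for cytotoxicity, read by sulforhodamine B assay, with a stated time of 72 h; a lower number here means a stronger inhibitor, a higher number a weaker inhibitor: compound 3 gives 24300 nM. Compound 1 `CN1Cc2ccc(OCc3ccccc3)cc2[C@@H](O)C1` reaches only a limit, > 100000 nM. Compound 2 `Cc1cccc(COc2ccc3c(c2)[C@@H](O)CN(C)C3)c1` likewise stops at a limit, > 50000 nM. The step of an at least 4.1-fold lower number from compound 1 to compound 3 (0.61 log units; beyond the scatter) and the step of an at least 2.0-fold lower number from compound 2 to compound 3 (0.31 log units; beyond the scatter) both show that introducing the 3-methoxyphenyl brings the number down. Compound 4 `CN1Cc2ccc(OCc3cccc(-c4ccc(Cl)cc4)c3)cc2[C@@H](O)C1` keeps a second ring but differs by 4-chlorophenyl in place of 3-methoxyphenyl on an aromatic carbon. Among the compounds with values here, no measured step exchanges one aryl ring for another, so this aryl-for-aryl change is expected to alter little: the estimated step is a 1.2-fold lower number from compound 3 to compound 4 (0.08 log units; within the scatter). Compound 4 is therefore expected to give 20000 nM, lying between 8000 nM and 60000 nM.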

Compound 4, half-maximal inhibitory concentration: 27300 nM
For compound 4 the middle estimate is 1.4-fold (0.14 log units) below the measured one, and the stated range covers the measured number.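

At this aromatic carbon, one aryl ring can now be compared directly with another: a 1.1-fold higher number from compound 3 to compound 4 (0.05 log units; within the scatter) in this assay shows that 4-chlorophenyl and 3-methoxyphenyl read alike. Each of the two steps from the compounds that stop at limits is only a floor: an at least 3.6-fold lower number from compound 1 to compound 4 (0.56 log units; beyond the scatter) clears the scatter against hydrogen, whereas an at least 1.8-fold lower number from compound 2 to compound 4 (0.26 log units; that floor lies within the scatter) does not establish a drop against methyl. Nothing shown explains why the two aryl rings match.

An amine or a carboxylic acid at this position remains untested among the compounds shown, so it is unclear whether the number would hold with such a group in place of the aryl ring.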